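The compounds below may be only part of what the source reports. "The series", "measured", "known", "first", "only" and "open" are said of these compounds alone.

Measured compounds:
compound 1, `CCN(CC)CCNC(=O)c1ccc(C(CC)(CC)c2ccc(OCC(=O)C(C)(C)C)c(C)c2)n1CC`, 30 nM
compound 2, `C#CCNC(=O)c1ccc(C(CC)(CC)c2ccc(OCC(O)C(C)(C)C)c(C)c2)n1CC`, 16200 nM
compound 3, `CC[C@@H](C)[C@H](NC(=O)c1ccc(C(CC)(CC)c2ccc(OCC(=O)C(C)(C)C)c(C)c2)n1CC)C(=O)O`, 1600 nM

All three values come from a functional assay on PC-3 cells (Homo sapiens), read by MTT assay, with a stated time of 48 h; a lower number here means a stronger inhibitor, a higher number a weaker inhibitor. Among these three numbers compound 2 stands highest, so it is the weakest inhibitor of the set: compound 3 gives 1600 nM, and compound 1 gives 30 nM, both clearly lower than the number for compound 2.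

Compound 4, `CCn1c(C(=O)N(C)CC(=O)O)ccc1C(CC)(CC)c1ccc(OCC(O)C(C)(C)C)c(C)c1`, has not been measured. It differs from compound 2 in one place: (carboxymethyl)(methyl)amino in place of propargylamino on a carbonyl carbon. The change therefore sits on the amide-type part of the shared core, and the entering group carries a carboxylic acid.

Among the measured compounds shown here, one measured step touches the same region. In it, the group on the amide-type nitrogen was exchanged for one bearing a carboxylic acid, and the result was a 53-fold higher number from compound 1 to compound 3 (1.73 log units; beyond the scatter). That step started from a very different group, a basic amine, so it is only a loose guide. For the measured compounds named here, there is no measured pair in which a propargylamino group is swapped for an acid-bearing group.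

Given that compound 2 already sits high, and that the only related step ran toward weaker inhibition, compound 4 is expected to show roughly a 1.1-fold lower number from compound 2 to compound 4 (0.03 log units; within the scatter) in this assay, with wide uncertainty. The estimate for compound 4 is 15000 nM, within a range from 3500 nM to 60000 nM.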

Compound 4, half-maximal inhibitory concentration: 23900 nM
Compound 4: middle estimate off by 1.6-fold (0.20 log units), on the low side; low and high end bracket the measured number.
By their numbers in this assay, from the lowest: compound 1; then compound 3; then compounds 2 and 4 (each within the scatter of the next).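

In this assay, exchanging propargylamino for (carboxymethyl)(methyl)amino on the carbonyl carbon gives a 1.5-fold higher number from compound 2 to compound 4 (0.17 log units; within the scatter), so compound 2 and compound 4 cannot be told apart here. Among the compounds shown here, the only earlier step at this part of the molecule, a 53-fold higher number from compound 1 to compound 3 (1.73 log units; beyond the scatter), also brought in a carboxylic acid and was large, so within these compounds an incoming acid does not always go with a large step. Compound 2 and compound 4 share a rest of the molecule that differs in another place from that of compound 1 and compound 3, and both start from a different group, so the two steps are not a like-for-like comparison. No measurement bearing on the reason for this result is available.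

From the compounds shown here alone, it remains open whether 2-(diethylamino)ethyl, the group on compound 1 at 30 nM, would give a similarly low number on the rest of the molecule of compound 2. Also open, going by these compounds, is how a longer chain ending in a dimethylamino group or in a carboxylic acid would read at this place on either version of the molecule.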